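This account rests on a few compounds, and the source may have more. Where it says the series, first, only, none or still open, it means among the compounds named here.

compound 1 `CCOc1ncnc2c1ncn2C[C@@H]1C[C@H](CO)c2ccccc21`: 24 ug/mL
compound 2 `OC[C@H]1C[C@@H](Cn2cnc3c(O)ncnc32)c2ccccc21`: 24 ug/mL
compound 3 `COc1ncnc2c1ncn2C[C@@H]1C[C@H](CO)c2ccccc21`: 24 ug/mL

In a functional assay on MOLT-4 cells (Homo sapiens) (a higher number here means a weaker inhibitor, a lower number a stronger inhibitor), compound 3 gives 24 ug/mL, level with the other two measured compounds. Compound 4 `CC(C)Nc1ncnc2c1ncn2C[C@@H]1C[C@H](CO)c2ccccc21` has not yet been measured. It differs from compound 3 as follows: isopropylamino in place of methoxy on an aromatic carbon. The group at this same aromatic carbon is also what varies among the measured compounds, so three steps bear on the change: no change at the digits printed from compound 1 to compound 2 (within the scatter), no change at the digits printed from compound 1 to compound 3 (within the scatter) and no change at the digits printed from compound 2 to compound 3 (within the scatter). Across hydrogen, methyl and ethyl on that oxygen, the value in this assay stays the same. None of these compounds carries a nitrogen at that carbon, however, so the new group goes beyond what has been tested, and the evidence is only indirect. Within the data shown here, with no measured step to suggest a direction, the expected result is a 1.1-fold lower number from compound 3 to compound 4 (0.04 log units; within the scatter), with no real shift beyond the scatter anticipated. The estimate for compound 4 is 22 ug/mL, with an expected range of 9 ug/mL to 50 ug/mL.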

Compound 4, half-maximal inhibitory concentration: 24 ug/mL
For compound 4 the middle estimate is 1.1-fold (0.04 log units) below the measured one; measured number inside the range.
By their numbers in this assay, from the lowest: compounds 1, 2, 3 and 4 (each within the scatter of the next).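

In this assay, the three earlier compounds vary only the group on an oxygen at this aromatic carbon, whereas compound 4 carries a nitrogen there in the form of isopropylamino. Replacing methoxy with this group gives no change at the digits printed from compound 3 to compound 4 (within the scatter), and the comparison with hydroxy gives no change at the digits printed from compound 2 to compound 4 (within the scatter), while the comparison with ethoxy gives no change at the digits printed from compound 1 to compound 4 (within the scatter). Among these four compounds, then, a link through nitrogen reads the same as a link through oxygen, even with isopropylamino, the group with the most heavy atoms of the four.

From the compounds shown here alone, no group at this carbon has yet moved the value, so it remains open whether a carboxylic acid, a chlorine atom or a longer amine chain such as n-butylamino would do so. What lies behind this flat reading stays unexplained, with no other data available that speak to it.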